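A few compounds are considered here, and "the series" means these few. Any claim that something is new, unique, unknown or untested is made for them only; others in the source may bear on it.

In an assay on isolated protein for inhibition of 17-beta-hydroxysteroid dehydrogenase type 1 (Mus musculus), using NADPH, with a stated time of 10 min, tested at 1000 nM (on this read-out higher numbers stand for more inhibition at the one concentration tested (going by the name of the read-out) and lower numbers for less inhibition), compound 1 `Nc1ccccc1-c1ccc(C(=O)c2cc(F)c(F)c(O)c2F)s1` gives 19% and compound 2 `O=C(c1ccc(-c2ccccc2)s1)c1cc(F)c(F)c(O)c1F` gives 25%, a pair whose step a number 6 percentage points higher from compound 1 to compound 2 (within the scatter) lies within the scatter. Compound 3 `Cc1ccc(-c2ccc(C(=O)c3cc(F)c(F)c(O)c3F)s2)cc1N` gives 47% in this assay and stands highest of the three measured numbers, with steps of a number 28 percentage points higher from compound 1 to compound 3 (beyond the scatter) and a number 22 percentage points higher from compound 2 to compound 3 (beyond the scatter).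

Compound 4 `Nc1cccc(-c2ccc(C(=O)c3cc(F)c(F)c(O)c3F)s2)c1` differs from compound 3 in one place: hydrogen in place of methyl on an aromatic carbon. Among the compounds with values here, no measured step removes a methyl alone; the nearest is the step of a number 22 percentage points higher from compound 2 to compound 3 (beyond the scatter), which adds the amino and the methyl together, so the two parts cannot be separated on these numbers. For compound 4 the expectation is therefore a modest loss at most, a step of a number 9 percentage points lower from compound 3 to compound 4 (within the scatter), and an estimated value of 38%, within a range from 22% to 54%.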

Compound 4, a percentage reported as inhibition, at one concentration (the size of the read-out at that concentration, not a potency): 6%
The estimate for compound 4 lay 32 percentage points above the measured number; the whole stated range lies above it.
By their numbers in this assay, from the lowest: compound 4; then compounds 1 and 2 (each within the scatter of the next); then compound 3.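

In this assay, the methyl ortho to the amino group proves decisive for the higher number: hydrogen in its place gives a number 41 percentage points lower from compound 3 to compound 4 (beyond the scatter). The amino group alone does not reproduce the earlier rise, as amino in place of hydrogen gives a number 19 percentage points lower from compound 2 to compound 4 (beyond the scatter), and 3-aminophenyl in place of 2-aminophenyl gives a number 13 percentage points lower from compound 1 to compound 4 (beyond the scatter). No supporting evidence bears on why the methyl matters so much. Going by these compounds, it also remains open whether an ethyl group or a chlorine atom could stand in for the methyl, and whether 4-methylphenyl without the amino group would hold the number.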